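The source may report more compounds than this note shows. Statements on the series, on what has been measured and on what is new or still open speak of the compounds shown alone.

Three compounds built on one shared core were examined in an assay on BTI-TN-5B1-4 cells for inhibition of Amine oxidase [flavin-containing] A (Homo sapiens), read by fluorescence and Amplex Red, using microsomes, with a stated time of 30 min; a lower number here means a stronger inhibitor, a higher number a weaker inhibitor. Compound 1 `C#CCOc1ccc(-c2cc(-c3ccc(OCC#C)cc3)nc(-c3ccccc3)n2)cc1` gives 25600 nM. Compound 3 `C#CCOc1ccc(-c2cc(-c3cccc(OCC#C)c3)nc(C)n2)cc1` gives 21100 nM, the lower of the two reported numbers, although its gap to compound 1 lies within the scatter. Compound 2 `C#CCOc1ccccc1-c1cc(-c2ccccc2OCC#C)nc(N)n1` is recorded in this assay as "not active" (no number reported). Compound 4 `C#CCOc1ccc(-c2cc(-c3cccc(OCC#C)c3)nc(-c3ccccc3)n2)cc1` has no result yet in this assay, and it differs from compound 3 by phenyl in place of methyl on an aromatic carbon. Going by the values given here, no measured pair shows this step directly, but compound 1 carries the same phenyl and gives 25600 nM close to compound 3. The step from compound 3 to compound 4 is therefore expected to be a 1.2-fold higher number from compound 3 to compound 4 (0.07 log units; within the scatter), nothing beyond the scatter. Compound 4 is expected to give 25000 nM, within a range of 8000 nM to 80000 nM.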

Compound 4, half-maximal inhibitory concentration: 25800 nM
For compound 4 the middle estimate is 1.0-fold (0.01 log units) below the measured one; the range from low to high includes it.
By their numbers in this assay, from the lowest: compounds 3, 1 and 4 (each within the scatter of the next).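

In this assay, phenyl in place of methyl on the aromatic carbon between two ring nitrogen atoms gives a 1.2-fold higher number from compound 3 to compound 4 (0.09 log units; within the scatter) and so stays within the scatter, although the group at this position is much larger. 3-(Propargyloxy)phenyl in place of 4-(propargyloxy)phenyl gives a 1.0-fold higher number from compound 1 to compound 4 (0.00 log units; within the scatter) and also stays within the scatter. Nothing available explains either result. As far as these compounds go, whether a carboxylic acid or a longer alkyl chain on this same aromatic carbon would also stay within the scatter remains open.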